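This account rests on a few compounds, and the source may have more. Where it says the series, first, only, none or still open, it means among the compounds named here.

Measured so far in a functional assay on DU-145 cells (Homo sapiens) for inhibition, read by trypan blue exclusion, with a stated time of 96 h; on this read-out lower numbers stand for stronger inhibition of growth and higher numbers for weaker inhibition of growth:
compound 1 `Cc1ccc(CS/C(=C/c2c(O)cc(O)cc2O)C(=O)c2ccc(Cl)cc2)cc1`: 50000 nM
compound 2 `Cc1ccc(S/C(=C/c2c(O)cc(O)cc2O)C(=O)c2ccc(Cl)cc2)cc1`: a limit of the assay, > 100000 nM
compound 3 `O=C(/C(=C\c1c(O)cc(O)cc1O)Sc1ccc(Br)cc1)c1ccc(Cl)cc1`: 50000 nM

Compound 3 stands level with compound 1 at the digits shown; the step between the two is no change at the digits printed from compound 1 to compound 3 (within the scatter). The value of compound 2 is a limit of the assay, (the limit of > 100000 nM in this assay, at which 1 of the 3 values shown sits). The steps of an at least 2.0-fold higher number from compound 1 to compound 2 (0.30 log units; that floor lies within the scatter) and an at least 2.0-fold lower number from compound 2 to compound 3 (0.30 log units; that floor lies within the scatter) are therefore only floors, and both floors lie within the scatter.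

The change to compound 4 `COc1ccccc1/C=C(/Sc1ccc(Br)cc1)C(=O)c1ccc(Cl)cc1` is 2-methoxyphenyl in place of 2,4,6-trihydroxyphenyl on a double-bonded chain carbon bound to a double-bonded chain carbon. All three measured steps alter the group on the sulfur, and none touches the aryl group on the double-bonded chain carbon, so none of them bears directly on this step. The three measured values sit at weak inhibition of growth and vary little across the sulfur changes, so no step beyond the scatter is expected in this assay in either direction. The expected step is no change at the digits printed from compound 3 to compound 4 (within the scatter). Compound 4 is expected to give about 50000 nM, with a range from 12000 nM to 150000 nM.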

Compound 4, concentration for 50% growth inhibition: 10000 nM
Beside the measured number, compound 4's estimate is 5.0-fold (0.70 log units) above it; the whole stated range lies above it.
By their numbers in this assay, from the lowest: compound 4; then compounds 1 and 3 (each within the scatter of the next). At a limit, above all of these: compound 2.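

In this assay, going by these compounds alone, the aryl group on the double-bonded chain carbon gives the first step that is printed as beyond the scatter: a 5.0-fold lower number from compound 3 to compound 4 (0.70 log units; beyond the scatter). The hydroxyl groups of 2,4,6-trihydroxyphenyl are therefore not required for this level of inhibition of growth, since the entering 2-methoxyphenyl has 0 hydrogen-bond donors. No measurement shown bears on why the step occurs.

The compounds shown do not separate the loss of the hydroxyl groups from the gain of the methoxy group; a plain phenyl or a 2-hydroxyphenyl at this place would separate them. Also open, on these data alone, are whether an amine or a carboxylic acid on this aryl group would shift the read-out further, and whether the step holds with 4-methylbenzyl on the sulfur.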